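The compounds below may be only part of what the source reports. "The series", "measured", "known", "first", "only" and "open" are said of these compounds alone.

Of the compounds shown here, three in a common series have been measured in a functional assay on MDA-MB-231 cells (Homo sapiens) for cytotoxicity, read by MTT assay, with a stated time of 72 h; a lower number here means a stronger inhibitor, a higher number a weaker inhibitor. Compound 1, `COc1ccc(-c2ccc(C)n2-c2ccc(-c3nc4ccc(F)cc4s3)cc2)cc1`, gives 19000 nM. Compound 2, `COc1cc2nc(-c3ccc(-n4c(C)ccc4-c4ccc(C)cc4)cc3)sc2c(OC)c1OC`, gives 12300 nM. Compound 3, `COc1cc2nc(-c3ccc(-n4c(C)ccc4-c4ccc(F)cc4)cc3)sc2c(OC)c1OC`, gives 13100 nM. Among these three numbers compound 3 holds the second highest place, but the spread is small: its nearest neighbour is compound 2, and its furthest is compound 1, and both gaps sit within the usual scatter of this assay. Among the measured compounds shown here, the one single-point step that has been measured, a 1.1-fold higher number from compound 2 to compound 3 (0.03 log units; within the scatter), likewise stays within the scatter.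

Compound 4, `COc1ccc(-c2ccc(C)n2-c2ccc(-c3nc4cc(OC)c(OC)c(OC)c4s3)cc2)cc1`, differs from compound 3 at the same ring position that was changed in that step: methoxy in place of fluoro on an aromatic carbon. For the measured compounds named here, the only measured step that bears on this change is the swap of methyl for fluoro at that position, a 1.1-fold higher number from compound 2 to compound 3 (0.03 log units; within the scatter), which moved the number hardly at all. Going by the values given here, no measured pair isolates the swap of fluoro for methoxy; compound 1 carries the methoxy group but on a different core, and its value and that of compound 3 are within the scatter of each other. The step from compound 3 to compound 4 is therefore expected to be a 1.1-fold higher number from compound 3 to compound 4 (0.03 log units; within the scatter), that is, no change beyond the scatter. Compound 4 is expected to give about 14000 nM, with a likely range from 6500 nM to 30000 nM.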

Compound 4, half-maximal inhibitory concentration: 12500 nM
Estimate against measurement, compound 4: 1.1-fold (0.05 log units) above; measured number inside the range.
By their numbers in this assay, from the lowest: compounds 2, 4, 3 and 1 (each within the scatter of the next).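

In this assay the position para to a large group, on the six-membered aromatic ring of carbon only, now has three measured groups, with methoxy joining fluoro and methyl, and two further steps can be read there (a 1.0-fold lower number from compound 3 to compound 4 (0.02 log units; within the scatter) and a 1.0-fold higher number from compound 2 to compound 4 (0.01 log units; within the scatter)). Both steps lie within the scatter, so these three groups cannot be told apart at this position, even though methoxy counts two heavy atoms and a hydrogen-bond acceptor where fluoro counts one heavy atom and no acceptor. Nothing measured here explains why the three groups read alike.

Still open, from the compounds shown here alone, is whether a quite different group at this position, such as an amine, a carboxylic acid or a longer chain like butoxy, would move the number beyond the scatter. Also open, going by these compounds, is whether methoxy in place of fluoro at this position would read the same way on another core, such as the core of compound 1.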